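Chloro to cyano on the core of compound 1

This account rests on a few compounds, and the source may have more. Where it says the series, first, only, none or still open, it means among the compounds named here.

Measured compounds:
compound 1 `CCCn1ccc2cc(-c3cccnc3)cc(Cl)c2c1=O`: 631 nM
compound 2 `CCCn1ccc2cc(-c3cncnc3)cc(Cl)c2c1=O`: 3980 nM
compound 3 `CCCn1ccc2cc(-c3cn[nH]c3)cc(Cl)c2c1=O`: 1580 nM

In a functional assay on CHO cells for agonist activity at metabotropic glutamate receptor 2 (Homo sapiens), read by GTPgammaS binding (a higher number here means that more compound is needed for the effect, a lower number that less compound is needed), compound 1 gives the lowest number of the three, with compound 3 a 2.5-fold higher number from compound 1 to compound 3 (0.40 log units; beyond the scatter) and compound 2 a 6.3-fold higher number from compound 1 to compound 2 (0.80 log units; beyond the scatter); the remaining step is a 2.5-fold lower number from compound 2 to compound 3 (0.40 log units; beyond the scatter). Compound 4 `CCCn1ccc2cc(-c3cccnc3)cc(C#N)c2c1=O` has not been measured. It differs from compound 1 in one place: cyano in place of chloro on an aromatic carbon. Going by the values given here, none of the measured steps touches this position; all three exchange the attached aromatic ring, so they give no guide to the size or direction of this change. Compound 4 is therefore expected to stay close to compound 1, with a 1.3-fold higher number from compound 1 to compound 4 (0.10 log units; within the scatter) not expected beyond the scatter. The estimate for compound 4 is 800 nM, within 250 nM to 2500 nM.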

Compound 4, half-maximal effective concentration: > 50100 nM
Compound 4 was reported as a limit; the forecaster's own chance of this, stated with the estimate: 5%; middle value at least 62-fold (1.79 log units) away from the limit.
By their numbers in this assay, from the lowest: compound 1; then compound 3; then compound 2. At a limit, above all of these: compound 4.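

In this assay, cyano in place of chloro on the aromatic carbon gives an at least 79-fold higher number from compound 1 to compound 4 (1.89 log units; beyond the scatter), a larger step than any of those among the attached aromatic rings. Going by these compounds alone, compound 4 stands at a limit of the assay and not at a number: the limit of > 50100 nM in this assay, at which 1 of the 4 values shown sits. So this position on the shared core, which no earlier step touched, can matter more to the number than the exchange of the attached ring does.

The compounds shown leave open whether this loss belongs to cyano alone or to other replacements of chloro. A fluoro, methyl or methoxy group at this position, or plain hydrogen, would begin to separate those readings.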